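Extending the butoxy chain of compound 1

A few compounds are considered here, and "the series" means these few. Any claim that something is new, unique, unknown or untested is made for them only; others in the source may bear on it.

Of the compounds shown here, two sharing one core have been measured in a functional assay on brain (Rattus norvegicus, strain Wistar) for inhibition; a lower number here means a stronger inhibitor, a higher number a weaker inhibitor. Compound 1 `CCCCOc1ccc(-c2c(C)[nH]c(=O)n2C2CCCCC2)cc1` gives 13900 nM. Compound 2 `CCCCCc1ccc(-c2c(C)[nH]c(=O)n2C2CCCCC2)cc1`, carrying pentyl in place of butoxy on an aromatic carbon, gives 10600 nM. The two numbers cannot be told apart, since a 1.3-fold lower number from compound 1 to compound 2 (0.12 log units; within the scatter). Compound 3 `CCCCCCCCCCOc1ccc(-c2c(C)[nH]c(=O)n2C2CCCCC2)cc1` has not yet been measured; it differs from compound 1 by hexyl in place of hydrogen on a saturated chain carbon, four bonds along the chain from an oxygen on an aromatic ring. Within the data shown here, no measured step shows what lengthening this chain does; the only measured step, from compound 1 to compound 2, exchanges one group for another of about the same size and stays within the scatter. With nothing pointing either way, only a small expected step is written down: a 1.4-fold lower number from compound 1 to compound 3 (0.14 log units; within the scatter). Compound 3 is estimated to give 10000 nM in this assay, within a range from 2500 nM to 40000 nM.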

Compound 3, half-maximal inhibitory concentration: 10500 nM
Beside the measured number, compound 3's estimate is 1.1-fold (0.02 log units) below it; measured number inside the range.
By their numbers in this assay, from the lowest: compounds 3, 2 and 1 (each within the scatter of the next).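

Compound 3 is the first of these compounds in which the butoxy chain itself is extended, and in this assay hexyl in place of hydrogen on a saturated chain carbon, four bonds along the chain from an oxygen on an aromatic ring, reads as a 1.3-fold lower number from compound 1 to compound 3 (0.12 log units; within the scatter). This position therefore accepts a hexyl extension without any difference this assay can resolve, so compound 1 and compound 3 cannot be told apart. Nothing available bears on why the added chain leaves the reading unresolved.

Open, from the compounds shown here alone, is whether any group at the end of this chain, such as an amine or a carboxylic acid, would produce a step beyond the scatter. Also open, going by these compounds, is whether a shorter chain, such as methoxy or ethoxy, would do so.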